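The source may report more compounds than this note shows. Statements on the series, on what has been measured and on what is new or still open speak of the compounds shown alone.

Measured so far:
compound 1 `CCC1=C(O)c2c(oc(-c3ccc(O)cc3)cc2=O)C(CC)(CC)C1=O` – 20.6 uM
compound 2 `CCC1=C(O)c2c(oc(-c3ccc(OC)cc3)cc2=O)C(CC)(CC)C1=O` – 17.7 uM
compound 3 `CCC1=C(O)c2c(oc(-c3ccc(COC)cc3)cc2=O)C(CC)(CC)C1=O` – a limit, > 52.4 uM

All three share one core and differ only in the group on the far aromatic ring. In a functional assay on KB cells (Homo sapiens) for antiproliferative activity, read by sulforhodamine B assay, with a stated time of 3 days (on this read-out higher numbers stand for an effect only at larger amounts of compound and lower numbers for an effect already at smaller amounts), compound 2 gives 17.7 uM, the lowest of the two plain numbers; compound 1 gives 20.6 uM, and the step of a 1.2-fold lower number from compound 1 to compound 2 (0.07 log units; within the scatter) lies within the scatter. For compound 3 this assay reports only a limit, > 52.4 uM; the steps of an at least 2.5-fold higher number from compound 1 to compound 3 (0.40 log units; beyond the scatter) and an at least 2.9-fold higher number from compound 2 to compound 3 (0.47 log units; beyond the scatter) point toward weaker activity once the group is a methoxymethyl.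

The unmeasured compound 4 `CCC1=C(O)c2c(oc(-c3ccc(OC)c(Cl)c3)cc2=O)C(CC)(CC)C1=O` keeps the methoxy of compound 2 and adds one atom: chloro in place of hydrogen on an aromatic carbon. Within the data shown here, no measured step adds a chloro to this ring, so the nearest guide is the small step from compound 1 to compound 2, which stayed within the scatter when the methoxy itself was introduced. A step no larger than the scatter is therefore expected, in either direction: a 1.0-fold higher number from compound 2 to compound 4 (0.01 log units; within the scatter). Compound 4 is thus estimated at 18 uM, most likely between 7 uM and 50 uM.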

Compound 4, concentration for half-maximal effect: 24.9 uM
Beside the measured number, compound 4's estimate is 1.4-fold (0.14 log units) below it; measured number inside the range.
By their numbers in this assay, from the lowest: compounds 2, 1 and 4 (each within the scatter of the next). At a limit, above all of these: compound 3.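

In this assay, among these compounds, a chloro ortho to the methoxy group gives the first look at this spot on the ring, and the two compounds cannot be told apart: a 1.4-fold higher number from compound 2 to compound 4 (0.15 log units; within the scatter). The added chlorine also leaves compound 4 indistinguishable from the hydroxy compound, with a 1.2-fold higher number from compound 1 to compound 4 (0.08 log units; within the scatter), so this ring has so far accepted a chloro here with no change beyond the scatter. Only an at least 2.1-fold lower number from compound 3 to compound 4 (0.32 log units; beyond the scatter) goes beyond the scatter, and that step rests on a limit: the limit of > 52.4 uM in this assay, at which 1 of the 4 values shown sits.

On these data alone, whether a bromo, a trifluoromethyl or an amine at this same spot would also stay within the scatter remains open. So does whether a chloro would behave the same way with a hydroxy group in place of the methoxy.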